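A few compounds are considered here, and "the series" means these few. Any claim that something is new, unique, unknown or untested is made for them only; others in the source may bear on it.

Of the compounds shown here, three sharing one core have been tested in a functional assay on SW-620 cells (Homo sapiens) for antiproliferative activity, read by MTT assay, with a stated time of 72 h; a lower number here means a stronger inhibitor, a higher number a weaker inhibitor. Compound 1 `O=C1O/C(=C\Cn2cc(-c3cc(C(F)(F)F)cc(C(F)(F)F)c3)nn2)C(OCc2ccccc2)=C1OCc1ccccc1` reaches only the limit of this assay, recorded as > 100000 nM. Compound 3 `COc1ccccc1-c1cn(C/C=C2\OC(=O)C(OCc3ccccc3)=C2OCc2ccccc2)nn1` likewise sits at a limit, recorded as > 100000 nM. Going by the values given here, compound 2 `O=C1O[C@H]([C@@H](O)Cn2cc(CNS(=O)(=O)c3ccc(F)cc3)nn2)C(OCc2ccccc2)=C1OCc1ccccc1` is the single member of the set with an actual number, giving 41100 nM in this assay, and there is no second measured number against which a step could be drawn. the limit of > 100000 nM in this assay, at which 2 of the 3 values shown sit, sums up where the other two sit.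

Compound 4 `O=C1O[C@H]([C@@H](O)Cn2cc(CCO)nn2)C(OCc2ccccc2)=C1OCc1ccccc1` has not yet been measured. It differs from compound 2 in one place: hydroxymethyl in place of ((4-fluorophenyl)sulfonyl)amino on a saturated chain carbon bound to an aromatic carbon. The group that leaves carries the six-membered aromatic ring of carbon only together with the sulfur, while the group that enters is the small hydroxymethyl. Among the compounds with values here, with no measured step to lean on, the expectation is a step toward weaker inhibition, somewhat beyond the usual scatter, expected as a 1.7-fold higher number from compound 2 to compound 4 (0.23 log units; within the scatter). Compound 4 is therefore estimated to give about 70000 nM in this assay, within a range from 25000 nM to 200000 nM, with a real chance that only a limit is reported.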

Compound 4, half-maximal inhibitory concentration: > 100000 nM
Compound 4: no number, only a limit; the forecaster's own chance of this, stated with the estimate: 40%; at least 1.4-fold (0.15 log units) between middle value and limit.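

In this assay compound 4 reaches only a limit, recorded as > 100000 nM. Going by these compounds alone, putting hydroxymethyl in place of ((4-fluorophenyl)sulfonyl)amino on a saturated chain carbon bound to an aromatic carbon gives an at least 2.4-fold higher number from compound 2 to compound 4 (0.38 log units; beyond the scatter), the first step that can be read in this set, and it fixes only the smallest possible size of the change, with its true size unknown. Within the data shown here, it shows that the one measurable number in the set does not survive this swap, in which the six-membered aromatic ring of carbon only and the sulfur leave together, so the series now rests almost entirely on a single mark: the limit of > 100000 nM in this assay, at which 3 of the 4 values shown sit.

With only this one pair, the compounds shown leave open which part of the departing group matters, the fluorinated aromatic ring, the sulfur with its two oxygens, or the nitrogen. A simple amine or a carboxylic acid at this place, or a longer chain ending in a hydroxyl group, would help to separate these parts, provided the values come out as numbers and not as limits.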